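The source may report more compounds than this note shows. Statements on the series, on what has been measured and on what is new or still open speak of the compounds shown alone.

The series shares one core. Compound 1 `COC(CCn1cnc2c(NCc3ccc(C(=O)Nc4ccccc4N)cc3)nc(Cl)nc21)OC`, compound 2 `CCC(C)n1cnc2c(NCc3ccc(C(=O)Nc4ccccc4N)cc3)nc(Cl)nc21` and compound 3 `Nc1ccccc1NC(=O)/C=C/c1ccc(Cn2cnc3c(Nc4cccc(Cl)c4)nc(Cl)nc32)cc1` have been measured; compound 4 `CCCCn1cnc2c(NCc3ccc(C(=O)Nc4ccccc4N)cc3)nc(Cl)nc21` has not. In a functional assay on HepG2 cells (Homo sapiens) for antiproliferative activity, read by CCK-8 assay, with a stated time of 72 h, tested at 2 uM (a lower number here means a weaker effect, a higher number a stronger effect of the compound at the concentration tested), compound 1 gives 8.52%, compound 2 gives 45% and compound 3 gives 35.8%. Compound 2 holds the highest of the three numbers, but compound 3 lies within the scatter of it, so no order between those two can be claimed; compound 1 sits well below both. For the measured compounds named here, the only measured step at the aromatic nitrogen of the five-membered ring is a number 36.5 percentage points higher from compound 1 to compound 2 (beyond the scatter), large and upward.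

Compound 4 differs from compound 2 as follows: butyl in place of sec-butyl on an aromatic nitrogen. That earlier step swapped out a substituent of different atoms and size, so it shows that this position can move the number, not how a rearrangement of the same atoms will. Going by the values given here, no measured pair tests an exchange of this kind. With the same atoms joined differently, the expected step is a number 3 percentage points lower from compound 2 to compound 4 (within the scatter), a change judged to stay within the scatter. Compound 4 is therefore estimated at 42%, with a range from 22% to 62%.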

Compound 4, a percentage reported as inhibition, at one concentration (the size of the read-out at that concentration, not a potency): 6.8%
Estimate against measurement, compound 4: 35.2 percentage points above; measured number outside the range, below it.
By their numbers in this assay, from the lowest: compounds 4 and 1 (each within the scatter of the next); then compounds 3 and 2 (each within the scatter of the next).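

In this assay, a number 38.2 percentage points lower from compound 2 to compound 4 (beyond the scatter) shows that at this position a rearrangement of the same four carbons can alone produce a large step, so sec-butyl and butyl cannot be treated as interchangeable on this aromatic nitrogen. The other new step, a number 1.7 percentage points lower from compound 1 to compound 4 (within the scatter), shows no separation between butyl and 3,3-dimethoxypropyl, so among the three groups compared here on the shared core, only sec-butyl stands apart, and the earlier step from compound 1 to compound 2 can no longer be read simply as a gain from replacing the dimethoxy-bearing chain with a plain four-carbon group. No evidence is available to explain the gap between the two butyl arrangements.

On these data alone, whether the higher number belongs to chain branching in general or to sec-butyl alone remains open, and isopropyl, isobutyl, tert-butyl or cyclobutyl on the same nitrogen would help separate those readings. Also open, as far as these compounds go, are how the two separate mirror-image forms of sec-butyl compare and whether a shorter chain such as ethyl, or a longer one such as pentyl, follows butyl or sec-butyl.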